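A Side Chain Swap at the Cytotoxicity Limit

The compounds below may be only part of what the source reports. "The series", "measured", "known", "first", "only" and "open" are said of these compounds alone.

- Compound 1 `CCCC(C)Nc1cc(Oc2c(OC)cc3cc(C#N)ccc3c2OC)nc(Nc2ccc(C#N)cc2)n1` gives > 125000 nM (a limit)
- Compound 2 `COc1cc2cc(C#N)ccc2c(OC)c1Oc1cc(NCC2CC2)nc(Nc2ccc(C#N)cc2)n1` gives > 125000 nM (a limit)
- Compound 3 `COc1cc2cc(C#N)ccc2c(OC)c1Oc1cc(NCC2CCOCC2)nc(Nc2ccc(C#N)cc2)n1` gives > 125000 nM (a limit)

These readings come from an ADME assay on MT4 cells (Homo sapiens) for cytotoxicity, read by MTT assay, with a stated time of 5 days (a higher number here means that more compound is tolerated, a lower number that less compound is tolerated), and none of them is an actual number. Compound 3 has no number of its own, and the same is true of the other two (the limit of > 125000 nM in this assay, at which 3 of the 3 values shown sit).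

The next move leads to compound 4 `COc1cc2cc(C#N)ccc2c(OC)c1Oc1cc(NCCCCO)nc(Nc2ccc(C#N)cc2)n1` with 3-hydroxypropyl in place of oxan-4-yl on a saturated chain carbon bound to a nitrogen on an aromatic ring. Three measured steps changed the group on that same nitrogen: a step that the two limits leave unreadable from compound 1 to compound 2 and a step that the two limits leave unreadable from compound 1 to compound 3 and a step that the two limits leave unreadable from compound 2 to compound 3 (the last one bears most directly on this move). None of them has a size that can be carried over.

The expectation therefore starts from compound 3 and its limit of > 125000 nM in this assay and no direction can be named. The estimate for this move is a number no higher from compound 3 to compound 4 (the limit leaves the size open) and it is expected to stay within the usual scatter. Compound 4 is estimated at 125000 nM with an expected range from 50000 nM to 250000 nM and quite possibly another limit in place of a number.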

Compound 4, half-maximal cytotoxic concentration: 39100 nM
For compound 4 the middle estimate is 3.2-fold (0.50 log units) above the measured one; the measured number lies below the stated range.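

In this assay, within the data shown here, the group on this nitrogen can change how much compound the cells tolerate, which the earlier compounds could not show: the change to compound 4 gives an at least 3.1-fold lower number from compound 3 to compound 4 (0.50 log units; beyond the scatter), along with an at least 3.1-fold lower number from compound 2 to compound 4 (0.50 log units; beyond the scatter) and an at least 3.1-fold lower number from compound 1 to compound 4 (0.50 log units; beyond the scatter). The steps among compound 1, compound 2 and compound 3 cannot be read, so compound 4, where 3-hydroxypropyl has no ring and has a hydrogen-bond donor while oxan-4-yl has a ring and no donor, gives the first readable difference at this place. Each readable step is only a minimum size, and compound 4 is the only compound here with an actual number: the limit of > 125000 nM in this assay, at which 3 of the 4 values shown sit.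

This single change removes the ring and adds the hydrogen-bond donor together, so the compounds shown do not tell which of the two goes with the lower number. Going by these compounds, it also stays open how a plain butyl chain, a chain ending in a methoxy group or a chain ending in an amine would read in this assay.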